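Swapping the aryl on the ring nitrogen of a hydroxamate

The source may hold more compounds than are shown below. What is called first, only, known or untested is meant among the compounds shown, and "the series" means these compounds.

Measured so far:
compound 1, `O=C(NO)c1ccc(NCc2nc(-c3ccccc3)nn2-c2ccccc2Cl)cc1` — 64.6%
compound 2, `CCc1ccc(-c2nc(CNc3ccc(C(=O)NO)cc3)n(-c3ccccc3)n2)cc1` — 54.6%
compound 3, `Cc1ccsc1-c1nc(CNc2ccc(C(=O)NO)cc2)n(-c2ccccc2)n1` — 72.1%

In an assay on Sf9 cells for inhibition of protein deacetylase HDAC6 (Homo sapiens), read by fluorescence, with a stated time of 40 min, tested at 100 nM (on this read-out higher numbers stand for more inhibition at the one concentration tested (going by the name of the read-out) and lower numbers for less inhibition), compound 1 gives 64.6%, the second highest of the three numbers. Its nearest neighbour is compound 3 at 72.1%, a gap within the scatter, and the furthest is compound 2 at 54.6%, also within the scatter. Within the data shown here, the one measured step in this set, a number 17.5 percentage points higher from compound 2 to compound 3 (beyond the scatter), concerns a group on an aromatic carbon, not the ring nitrogen, so it does not bear directly on the change now at hand.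

Compound 4, `Cc1cc(C)cc(-n2nc(-c3ccccc3)nc2CNc2ccc(C(=O)NO)cc2)c1`, differs from compound 1 at the ring nitrogen: 3,5-dimethylphenyl in place of 2-chlorophenyl on an aromatic nitrogen. Among the measured compounds shown here, no measured pair shows what changing the group at this place does to the read-out. The expectation therefore rests on compound 1 alone, and the step of a number 2.6 percentage points lower from compound 1 to compound 4 (within the scatter) is expected to stay within the scatter. For compound 4 a value of 62% is estimated, in the range 42% to 80%.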

Compound 4, a percentage reported as inhibition, at one concentration (the size of the read-out at that concentration, not a potency): 49.8%
The estimate for compound 4 lay 12.2 percentage points above the measured number; the measured number falls inside the stated range.
By their numbers in this assay, from the lowest: compounds 4, 2, 1 and 3 (each within the scatter of the next, the first and the last beyond it).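

In this assay, among these compounds, the group on the aromatic nitrogen proves not to be interchangeable: 3,5-dimethylphenyl in place of 2-chlorophenyl gives a number 14.8 percentage points lower from compound 1 to compound 4 (beyond the scatter) and is the first measured step at this place. The read-out thus separates two groups that each bring one six-membered aromatic ring of carbon only, with neither carrying a hydrogen-bond donor, a hydrogen-bond acceptor or a net charge. No measurement at hand explains the step, and this single pair cannot separate the loss of the chlorine from the arrival of the two methyl groups.

Going by these compounds, it remains open whether a single methyl, a methoxy or an amine on this aryl ring would give a number nearer that of compound 1 or that of compound 4. On these data alone, it also remains open whether the step would persist with the groups that compound 2 and compound 3 carry on the aromatic carbon.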